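From Ethylcarbamoyl to Methyloxazolyl: an Untested Direction

A few compounds are considered here, and "the series" means these few. Any claim that something is new, unique, unknown or untested is made for them only; others in the source may bear on it.

Compound 1 `CCNC(=O)C1=C(C)NC(=O)NC1c1ccco1` stands second highest of three numbers that all lie within the scatter of one another in an assay on membranes from HeLa cells for displacement of a labelled ligand from adenosine receptor A3 (Homo sapiens), read by scintillation counting, with a stated time of 180 min, tested at 1 uM (on this read-out lower numbers stand for less inhibition and higher numbers for more inhibition at the one concentration tested (going by the name of the read-out)), where compound 1 gives 3%. Its nearest neighbour is compound 2 `CCNC(=O)C1=C(C)NC(=O)NC1c1cccs1`, which in this assay gives 4%, and the furthest is compound 3 `CCNC(=O)C1=C(C)NC(=O)NC1c1ccsc1`, which gives 1%. The three steps among them are small: a number 1 percentage points higher from compound 1 to compound 2 (within the scatter), a number 2 percentage points lower from compound 1 to compound 3 (within the scatter) and a number 3 percentage points lower from compound 2 to compound 3 (within the scatter). Compound 4 `CC1=C(c2ncc(C)o2)C(c2ccco2)NC(=O)N1` departs from compound 1 at a different place: 5-methyl-1,3-oxazol-2-yl in place of ethylcarbamoyl on a double-bonded ring carbon. Within the data shown here, no measured step touches this position; each of the measured steps exchanges the group on the saturated ring carbon, and none of them moved the read-out beyond the scatter. Among the measured compounds shown here, the measured compounds all sit near the bottom of the read-out, and no step among them points upward, so only a small step is expected, a number 3 percentage points higher from compound 1 to compound 4 (within the scatter). Compound 4 is accordingly estimated at 6%, with a range from -8% to 25%.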

Compound 4, a percentage reported as inhibition, at one concentration (the size of the read-out at that concentration, not a potency): 4%
For compound 4 the middle estimate is 2 percentage points above the measured one; low and high end bracket the measured number.
By their numbers in this assay, from the lowest: compounds 3, 1, 2 and 4 (each within the scatter of the next).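

Among these compounds, the exchange at the double-bonded ring carbon is the first step away from the saturated ring carbon, and in this assay it gives a number 1 percentage points higher from compound 1 to compound 4 (within the scatter) and so stays as small as the earlier steps. Ethylcarbamoyl, with 1 hydrogen-bond donor, can thus give way to 5-methyl-1,3-oxazol-2-yl, with 0 hydrogen-bond donors and a five-membered aromatic ring, without the number leaving the scatter around compound 1. No measurement to hand offers a reason for this result.

With every number near the bottom of the read-out, these compounds cannot show whether the position matters in a compound that inhibits more. From the compounds shown here alone, whether an amine, a carboxylic acid or a longer chain on the same ring carbon would move the number beyond the scatter remains open.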